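Trading an open amine chain for an aminocyclohexyl ring

A few compounds are considered here, and "the series" means these few. Any claim that something is new, unique, unknown or untested is made for them only; others in the source may bear on it.

Compound 1 `C/C(=C/CN(C[C@H]1Cc2ccccc2CN1)[C@H]1CCCc2cccnc21)CN` is the strongest of three compounds in a functional assay on CCRF-CEM cells for antagonist activity at C-X-C chemokine receptor type 4 (Homo sapiens), read by calcium flux, with stated times of 25 min and 90 s (a lower number here means a stronger inhibitor, a higher number a weaker inhibitor), where compound 1 gives 8.6 nM. Compound 3 `C/C(CN)=C(\F)CN(C[C@H]1Cc2ccccc2CN1)[C@H]1CCCc2cccnc21` gives 28 nM, and compound 2 `C/C(CN(C[C@H]1Cc2ccccc2CN1)[C@H]1CCCc2cccnc21)=C(/F)CN` gives 1800 nM; each differs from compound 1 only in the side chain carried on the amine nitrogen. Compound 4 `N[C@H]1CC[C@H](N(C[C@H]2Cc3ccccc3CN2)[C@H]2CCCc3cccnc32)CC1` alters that same chain more deeply: a group of 7 heavy atoms (6 carbon, 1 nitrogen; one six-membered non-aromatic ring of carbon only) in place of a group of 6 heavy atoms (5 carbon, 1 nitrogen; no ring), on an amine nitrogen. The measured steps of a 3.3-fold higher number from compound 1 to compound 3 (0.51 log units; beyond the scatter) and a 210-fold higher number from compound 1 to compound 2 (2.32 log units; beyond the scatter) show that even small edits to this chain cost anything from a modest to a large amount, so a weakening is expected for compound 4 as well, estimated at a 4.7-fold higher number from compound 1 to compound 4 (0.67 log units; beyond the scatter). Compound 4 is therefore expected to give about 40 nM, within a range from 6 nM to 300 nM.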

Compound 4, half-maximal inhibitory concentration: 34 nM
Estimate against measurement, compound 4: 1.2-fold (0.07 log units) above, within the range that was stated.
By their numbers in this assay, from the lowest: compound 1; then compounds 3 and 4 (each within the scatter of the next); then compound 2.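

Putting 4-aminocyclohexyl on this amine nitrogen costs only a modest step (a 4.0-fold higher number from compound 1 to compound 4 (0.60 log units; beyond the scatter)), so the position accepts a ring as well as an open chain with a double bond. The ring cannot be told apart from the chain of compound 3 (a 1.2-fold higher number from compound 3 to compound 4 (0.08 log units; within the scatter)), and it is far stronger than the chain of compound 2 (a 53-fold lower number from compound 2 to compound 4 (1.72 log units; beyond the scatter)). From the compounds shown here alone, whether a carboxylic acid or a longer chain ending in an amine on that ring would keep this strength stays open. Nothing available accounts for these numbers.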